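The compounds below may be only part of what the source reports. "The series", "measured", "known", "first", "only" and "open" are said of these compounds alone.

In a functional assay on HEK293 cells for agonist activity at Free fatty acid receptor 1 (Homo sapiens), read by calcium flux (on this read-out higher numbers stand for an effect only at larger amounts of compound and lower numbers for an effect already at smaller amounts), compound 1 `CCCOc1ccc(C(CC(=O)O)c2ccccc2)cc1` gives 4.8 uM, and compound 2 `CCCCOc1ccc(C(CC(=O)O)c2ccccc2)cc1` gives 1.2 uM. Among these two numbers compound 2 stands lowest: the change a 4.0-fold lower number from compound 1 to compound 2 (0.60 log units; beyond the scatter) is the only measured step here. Compound 3 `O=C(O)CC(c1ccccc1)c1ccc(OCCCC(F)(F)F)cc1` differs from compound 2 in one place: trifluoromethyl in place of methyl on a saturated chain carbon, three bonds along the chain from an oxygen on an aromatic ring. Among the measured compounds shown here, no measured step alters a group in this way; the one measured step, from compound 1 to compound 2, concerns lengthening the chain by methyl, so it bears on compound 3 only in showing that this chain end tolerates a small change without loss in this assay. For the measured compounds named here, with no comparable fluorine step to lean on, a step of no more than modest size in either direction is expected, with a 1.2-fold lower number from compound 2 to compound 3 (0.08 log units; within the scatter) as the estimate. For compound 3 the expected value in this assay is 1 uM, within a range from 0.3 uM to 3.5 uM.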

Compound 3, concentration for half-maximal effect: 3.16 uM
The estimate for compound 3 lay 3.2-fold (0.50 log units) below the measured number; the range from low to high includes it.
By their numbers in this assay, from the lowest: compound 2; then compounds 3 and 1 (each within the scatter of the next).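

In this assay the end of this chain responds to more than its length: trifluoromethyl in place of methyl gives a 2.6-fold higher number from compound 2 to compound 3 (0.42 log units; beyond the scatter), so the better value of compound 2 does not carry over when the end of the butyl chain is fluorinated. Measured against the shorter propyl chain, the same group gives a 1.5-fold lower number from compound 1 to compound 3 (0.18 log units; within the scatter), which leaves the 4,4,4-trifluorobutyl chain of compound 3 and the propyl chain of compound 1 indistinguishable on this read-out. No available measurement accounts for this result.

Still open, from the compounds shown here alone, is how a longer chain, such as pentyl, would read at this position, and whether a single fluorine at the chain end would behave like methyl or like trifluoromethyl. A hydroxyl or a cyclopropyl group at the same carbon would also show whether trifluoromethyl's result is specific to that group.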